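A naphthyl group replaces tolyl on a shared aromatic core

A few compounds are considered here, and "the series" means these few. Any claim that something is new, unique, unknown or untested is made for them only; others in the source may bear on it.

Compound 1 `Cc1ccc(-c2c3ccc4ccccc4c3nc3c2c(C)nc2c4ccccc4ccc32)cc1` is one of three measured compounds built on the same core. In a functional assay, read by spectrophotometry, with a stated time of 15 min (a lower number here means a stronger inhibitor, a higher number a weaker inhibitor), compound 1 gives 68.7 ug/mL, a number that sits in the middle of the three, all of which lie within the usual scatter of one another. Compound 2 `Cc1nc2c3ccccc3ccc2c2nc3c(ccc4ccccc43)c(-c3cccc([N+](=O)[O-])c3)c12` gives 54.2 ug/mL and compound 3 `Cc1nc2c3ccccc3ccc2c2nc3c(ccc4ccccc43)c(-c3ccccc3)c12` gives 84.6 ug/mL. The measured steps are small: a 1.3-fold lower number from compound 1 to compound 2 (0.10 log units; within the scatter), a 1.2-fold higher number from compound 1 to compound 3 (0.09 log units; within the scatter) and a 1.6-fold higher number from compound 2 to compound 3 (0.19 log units; within the scatter). Compound 4 `Cc1nc2c3ccccc3ccc2c2nc3c(ccc4ccccc43)c(-c3cccc4ccccc34)c12` differs from compound 1 in one place: naphthalen-1-yl in place of 4-methylphenyl on an aromatic carbon. For the measured compounds named here, no measured step swaps in a naphthalen-1-yl, but the three changes already seen at this carbon all stayed within the scatter, so for compound 4 a step of about a 1.1-fold lower number from compound 1 to compound 4 (0.02 log units; within the scatter) is expected, with no move beyond the scatter. Compound 4 is estimated at 65 ug/mL, with a likely range from 30 ug/mL to 140 ug/mL.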

Compound 4, half-maximal inhibitory concentration: 64.3 ug/mL
Beside the measured number, compound 4's estimate is 1.0-fold (0.00 log units) above it, within the range that was stated.
By their numbers in this assay, from the lowest: compounds 2, 4, 1 and 3 (each within the scatter of the next).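

In this assay, a two-ring group at this carbon reads much like the one-ring groups: naphthalen-1-yl stays within the scatter when compared with 4-methylphenyl (a 1.1-fold lower number from compound 1 to compound 4 (0.03 log units; within the scatter)), phenyl (a 1.3-fold lower number from compound 3 to compound 4 (0.12 log units; within the scatter)) and 3-nitrophenyl (a 1.2-fold higher number from compound 2 to compound 4 (0.07 log units; within the scatter)). Across these four compounds, adding a second aromatic ring therefore moves the number no more than the substituent changes on a single ring did. No measurement at hand explains this lack of separation. Still open, from the compounds shown here alone, is whether a non-aromatic group at this carbon, such as an amine or a carboxylic acid, would move the number beyond the scatter.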